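The source may report more compounds than this note shows. Statements on the series, on what has been measured and on what is new or still open speak of the compounds shown alone.

Compound 1 `Cc1ccccc1C(CCC(=O)O)Oc1cccc(OCc2ccsc2)c1` opens the series; in an assay on cerebellum for binding affinity to Endothelin receptor type B (Rattus norvegicus) (a lower number here means a stronger inhibitor, a higher number a weaker inhibitor), compound 1 gives > 30000 nM, which is a limit of the assay rather than a number. Compound 2 `Cc1ccccc1C(CCC(=O)O)Oc1cc(OCc2ccsc2)ccc1C(N)=O` carries a carbamoyl group in place of a hydrogen on an aromatic carbon, and in this assay compound 2 gives 10000 nM. Compound 1 sits at the limit of > 30000 nM in this assay, at which 1 of the 2 values shown sits, so the value of compound 2 is the only number shown. That single change brought an at least 3.0-fold lower number from compound 1 to compound 2 (0.47 log units; beyond the scatter). Compound 3 `Cc1ccccc1C(CCC(=O)O)Oc1cc(OCc2ccsc2)ccc1-c1ncc[nH]1` continues from compound 2 with 1H-imidazol-2-yl in place of carbamoyl on an aromatic carbon. Among the compounds with values here, the only measured step, an at least 3.0-fold lower number from compound 1 to compound 2 (0.47 log units; beyond the scatter), shows that a group on this carbon can lower the number, but no measured step exchanges carbamoyl for another group, so it guides the expectation only loosely. A small gain or a step within the scatter is expected, a 2.0-fold lower number from compound 2 to compound 3 (0.30 log units; within the scatter). For compound 3 in this assay the estimate is 5000 nM, expected to lie between 1000 nM and 30000 nM.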

Compound 3, half-maximal inhibitory concentration: > 10000 nM
Compound 3 was reported as a limit; the forecaster's own chance of this, stated with the estimate: 20%; at least 2.0-fold (0.30 log units) between middle value and limit.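

In this assay compound 3 gives > 10000 nM, which is a limit of the assay and not a number. Placing 1H-imidazol-2-yl on this carbon in place of carbamoyl brings a number no lower from compound 2 to compound 3 (the limit leaves the size open), so a five-membered aromatic ring with the same hydrogen-bond donor and acceptor counts as carbamoyl, but more heavy atoms, shows no gain over carbamoyl at this position. The step from compound 1 to compound 3 cannot be read, as both values are limits.

Going by these compounds, whether 1H-imidazol-2-yl does anything at all compared with hydrogen therefore stays open. On these data alone, it is also open whether a smaller group on this carbon, such as a carboxylic acid or an aminomethyl group, would give a lower number than carbamoyl.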